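This account rests on a few compounds, and the source may have more. Where it says the series, first, only, none or still open, it means among the compounds named here.

Compound 1 `COc1cc(Oc2cc(C)cc(C)c2)cc(Nc2ccc(C#N)cc2)n1` and compound 2 `COc1cc(Oc2c(C)cc(C)cc2C)cc(Nc2ccc(C#N)cc2)n1` share one core. Compound 3 `Cc1cc(C)cc(Oc2cc(Nc3ccc(C#N)cc3)[nH]c(=O)c2Cl)c1` and compound 4 `Cc1cc(C)c(Oc2cc(Nc3ccc(C#N)cc3)[nH]c(=O)c2Cl)c(C)c1` share another core, and the difference between the two cores is not broken down here. In an ADME assay on MT4 cells (Homo sapiens) for cytotoxicity, read by MTT assay, with a stated time of 5 days (a lower number here means that less compound is tolerated, a higher number that more compound is tolerated), compound 1 gives 20000 nM and compound 2 gives 29000 nM while compound 3 gives 21000 nM in this assay. The change 2,4,6-trimethylphenyl in place of 3,5-dimethylphenyl on an oxygen on an aromatic ring made a 1.5-fold higher number from compound 1 to compound 2 (0.16 log units; within the scatter) in this assay. The same change 2,4,6-trimethylphenyl in place of 3,5-dimethylphenyl on an oxygen on an aromatic ring is made from compound 3 to compound 4 and compound 4 is not yet measured in this assay. Because the earlier pair gave a 1.5-fold higher number from compound 1 to compound 2 (0.16 log units; within the scatter) in this assay a step of about a 1.3-fold higher number from compound 3 to compound 4 (0.12 log units; within the scatter) is expected here and rests on that single pair alone. Compound 4 is therefore estimated at 28000 nM in this assay with a range from 14000 nM to 56000 nM expected.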

Compound 4, half-maximal cytotoxic concentration: > 329000 nM
Compound 4 was reported as a limit; the forecaster's own chance of this, stated with the estimate: 20%; middle value at least 11-fold (1.07 log units) away from the limit.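

In this assay, 2,4,6-trimethylphenyl in place of 3,5-dimethylphenyl on an oxygen on an aromatic ring gives an at least 15-fold higher number from compound 3 to compound 4 (1.19 log units; beyond the scatter), and this step does not match the earlier one in size: the same change on two cores in this assay, a 1.5-fold higher number (0.16 log units; within the scatter) from compound 1 to compound 2 and an at least 15-fold higher number (1.19 log units; beyond the scatter) from compound 3 to compound 4, at least 10-fold (1.03 log units) apart, beyond the scatter of two such steps.
On these data alone, for compound 4, > 329000 nM is a limit of the assay and not a number, so the full size of the step stays unknown: the limit of > 329000 nM in this assay, at which 1 of the 4 values shown sits.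
The two pairs show that the step on one core does not set the size of the step on the other, but they do not show why or what happens on any further core.

As far as these compounds go, it remains open how this assay responds on either core to an amine or a carboxylic acid in place of the nitrile. From the compounds shown here alone, the effect of a longer chain in place of either aryl group also remains open.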